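Adding an amino side chain to the pyrimidine of compound 1

A few compounds are considered here, and "the series" means these few. Any claim that something is new, unique, unknown or untested is made for them only; others in the source may bear on it.

Measured compounds:
compound 1, `O=C(Nc1ccc(Oc2ccncn2)cc1)Nc1cccc(C(F)(F)F)c1`: 160 nM
compound 2, `CNc1cc(Oc2ccc(NC(=O)Nc3cccc(C(F)(F)F)c3)c(F)c2)ncn1`: 63 nM
compound 3, `CNc1cc(Oc2ccc(NC(=O)Nc3cccc(C(C)(F)F)c3)cc2)ncn1`: 40 nM

All three were tested in an assay on isolated protein for inhibition of serine/threonine-protein kinase TNNI3K (Homo sapiens); a lower number here means a stronger inhibitor, a higher number a weaker inhibitor. Compound 1 gives the highest of the three numbers, so on these numbers it is the weakest inhibitor of the set: compound 2 and compound 3 both lie beyond the scatter below it. No single-change pair exists among the measured compounds, so nothing can be said about the cause of those gaps; compound 2 and compound 3 each differ from compound 1 in more than one place, though both carry a methylamino group on the shared core where compound 1 carries only hydrogen.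

Compound 4, `CC(C)(O)CNc1cc(Oc2ccc(NC(=O)Nc3cccc(C(F)(F)F)c3)cc2)ncn1`, has not yet been measured. It differs from compound 1 in one place: (2-hydroxy-2-methylpropyl)amino in place of hydrogen on an aromatic carbon. The new group sits where compound 2 and compound 3 carry their methylamino group, and those two compounds give the lower numbers in this assay. On that basis a step of moderate size toward a lower number is expected, a 3.2-fold lower number from compound 1 to compound 4 (0.51 log units; beyond the scatter), though it remains an expectation. Compound 4 is estimated at 50 nM, with a range from 15 nM to 160 nM.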

Compound 4, half-maximal inhibitory concentration: 40 nM
Compound 4: the middle estimate sits 1.3-fold (0.10 log units) above what was measured; the measured number falls inside the stated range.
By their numbers in this assay, from the lowest: compounds 3, 4 and 2 (each within the scatter of the next); then compound 1.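

For the compounds shown here, the first change in this set made at only one place can now be read: in this assay, (2-hydroxy-2-methylpropyl)amino in place of hydrogen on an aromatic carbon gives a 4.0-fold lower number from compound 1 to compound 4 (0.60 log units; beyond the scatter). This shows that this position, next to the ring nitrogen, can carry a branched chain ending in a hydroxyl group and still give a lower number, something compound 2 and compound 3 could not show, as each differs from compound 1 in more than one place. Nothing given here explains why the number falls with this change.

The compounds shown leave open how much of the step comes from the amino nitrogen and how much from the rest of the chain, including its hydroxyl group. At this same position, a plain amino group, methylamino on the otherwise unchanged core of compound 1, or a longer chain ending in a carboxylic acid would each help separate those contributions.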